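The source may hold more compounds than are shown below. What is called first, only, known or untested is meant among the compounds shown, and "the series" means these compounds.

Measured so far
compound 1, `CN1CCC(C(=O)N2Cc3c(NC(=O)c4ccsc4)n[nH]c3C2(C)C)CC1`, 140 nM
compound 2, `CC(C)(C)C(=O)N1Cc2c(NC(=O)c3cccnc3)n[nH]c2C1(C)C`, 690 nM

Two compounds of the series have numbers in a functional assay on A2780 cells (Homo sapiens) for antiproliferative activity, read by fluorescence, with a stated time of 72 h; a higher number here means a weaker inhibitor, a lower number a stronger inhibitor. Compound 1 gives 140 nM in this assay; compound 2 gives 690 nM. Compound 2 therefore stands with the higher of the two numbers, and the gap down to compound 1 lies beyond the usual scatter. The two compounds differ in more than one place, so nothing further is read from that pair than what the two values show.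

The next compound, compound 3 `CC(C)(C)C(=O)N1Cc2c(NC(=O)c3ccc(F)cc3)n[nH]c2C1(C)C`, is drawn from compound 2 by one exchange at the amide side: 4-fluorophenyl in place of pyridin-3-yl on a carbonyl carbon.

Among the compounds with values here, no single-point step between measured compounds is available, so the size of this step is open. With only the values of compound 1 and compound 2 as anchors, the change from pyridin-3-yl to 4-fluorophenyl is expected to move the number only moderately, if at all beyond the scatter, with a slight lean towards a lower number. For compound 3 the expected step is a 1.4-fold lower number from compound 2 to compound 3 (0.14 log units; within the scatter). Compound 3 is thus estimated at 500 nM in this assay, within a range from 150 nM to 1800 nM.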

Compound 3, half-maximal inhibitory concentration: 270 nM
For compound 3 the middle estimate is 1.9-fold (0.27 log units) above the measured one; low and high end bracket the measured number.
By their numbers in this assay, from the lowest: compounds 1 and 3 (each within the scatter of the next); then compound 2.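

Within the data shown here, on the carbonyl carbon whose other neighbour is the amide-type nitrogen, the aryl group gives the first single exchange that can be read: in this assay, 4-fluorophenyl in place of pyridin-3-yl gives a 2.6-fold lower number from compound 2 to compound 3 (0.41 log units; beyond the scatter) and counts as a modest step beyond the scatter. Pyridin-3-yl carries a hydrogen-bond acceptor and 4-fluorophenyl carries none, so in this one pair an acceptor in the ring is not required to reach the lower number, although a single pair cannot show how general that is. Nothing at hand gives a measured reason for the size or direction of this step.

The exchange removes the ring nitrogen and adds a fluorine in one move, so the compounds shown do not separate the two changes; plain phenyl and 4-chlorophenyl on the same carbonyl carbon would bear on that question. Among these compounds, it also remains open whether the same exchange gives a step of similar size when the acyl group of compound 2 and compound 3 is replaced by the one carried by compound 1.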